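Methyl on a Ring Nitrogen, Tried on Two Cores

The source may hold more compounds than are shown below. What is called first, only, known or untested is meant among the compounds shown, and "the series" means these compounds.

Compound 1 `Nc1n[nH]c2cc(-c3ccccn3)[nH]c(=O)c12` and compound 3 `Cn1nc(N)c2c(=O)[nH]c(-c3ccccn3)cc21` share one core. In an assay on isolated protein for inhibition of serine/threonine-protein kinase D2 (Homo sapiens), read by mobility shift assay, tested at 30 uM (on this read-out higher numbers stand for more inhibition at the one concentration tested (going by the name of the read-out) and lower numbers for less inhibition), compound 1 gives 33%, while compound 3 gives 17%. The change between them is methyl in place of hydrogen on an aromatic nitrogen, and it produced a number 16 percentage points lower from compound 1 to compound 3 (beyond the scatter). Compound 2 `Cc1cc2[nH]nc(N)c2c(N2CCCCC2)n1` rests on a different core; the difference between the two cores is not broken down here. In this assay compound 2 gives 14%, the lowest of the three numbers, its gap to compound 3 within the scatter and its gap to compound 1 beyond it. Compound 4 `Cc1cc2c(c(N)nn2C)c(N2CCCCC2)n1` arises from compound 2 by methyl in place of hydrogen on an aromatic nitrogen, the same change at the same place. Compound 4 is expected to show a step of a number 10 percentage points lower from compound 2 to compound 4 (within the scatter) in this assay, because a number 16 percentage points lower from compound 1 to compound 3 (beyond the scatter) lay beyond the scatter in the same direction. Compound 4 is therefore estimated at 4%, likely between -6% and 16%.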

Compound 4, a percentage reported as inhibition, at one concentration (the size of the read-out at that concentration, not a potency): 16%
Compound 4: the middle estimate sits 12 percentage points below what was measured; the measured number falls inside the stated range.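

In this assay, methyl in place of hydrogen on an aromatic nitrogen gave a number 2 percentage points higher from compound 2 to compound 4 (within the scatter). The change therefore did not carry over from one core to the other with the same size: the same change on two cores in this assay, a number 16 percentage points lower (beyond the scatter) from compound 1 to compound 3 and a number 2 percentage points higher (within the scatter) from compound 2 to compound 4, 18 percentage points apart, beyond the scatter of two such steps This shows that, for these two pairs, the step read on one core could not be transferred to the other, but with a single pair per core it does not show which difference between the cores matters, nor how the change would read on a third core.

The compounds shown leave open how a longer chain such as ethyl, placed on that same aromatic nitrogen, would read on either core. They also leave open whether a cyclopropyl group there would follow either step.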